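From compound 3 to compound 4: a large added group

The source may report more compounds than this note shows. Statements on the series, on what has been measured and on what is new or still open speak of the compounds shown alone.

compound 1 `O=C(O)c1ccccc1-c1ccccc1C(=O)NCCCCCCCn1cc(-c2cccnc2)nn1` reads > 500 nM (a limit of the assay, not a number)
compound 2 `O=C(NCCCCCCCn1cc(-c2cccnc2)nn1)c1ccccc1-c1cccnc1` reads 36.5 nM
compound 3 `O=C(NCCCCCCCn1cc(-c2cccnc2)nn1)c1ccccc1-n1ccnn1` reads 35.4 nM

All three values come from an ADME assay on SH-SY5Y cells (Homo sapiens) for cytotoxicity, read by MTT assay, with a stated time of 48 h (on this read-out higher numbers stand for an effect only at larger amounts of compound and lower numbers for an effect already at smaller amounts), and compound 4 `CC(C)N1CCN(Cc2cn(-c3ccccc3C(=O)NCCCCCCCn3cc(-c4cccnc4)nn3)nn2)CC1` has yet to be measured there. Compound 3 sits at the low end of the numbers shown, level with the only other exact value. The gap is a 1.0-fold lower number from compound 2 to compound 3 (0.01 log units; within the scatter), so neither ranks ahead of the other.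

The next change is (4-isopropylpiperazin-1-yl)methyl in place of hydrogen on an aromatic carbon, with (4-isopropylpiperazin-1-yl)methyl in place of hydrogen on an aromatic carbon. Among the measured compounds shown here, three measured steps bear on it. Replacing the 2-carboxyphenyl group gave large steps, namely an at least 13-fold lower number from compound 1 to compound 2 (1.13 log units; beyond the scatter) and an at least 14-fold lower number from compound 1 to compound 3 (1.14 log units; beyond the scatter), so changes in this part of the molecule can matter a great deal. Neither step resembles the new change closely, however. The step that introduces the 1H-1,2,3-triazol-1-yl group, which now receives the addition, stays within the scatter. For the measured compounds named here, no measured step adds a group of this size, so the range has to stay wide. The estimated change is a 1.4-fold higher number from compound 3 to compound 4 (0.15 log units; within the scatter), so no step beyond the scatter is expected. For compound 4 the expected value is 50 nM, with 10 nM and 350 nM as the estimated ends of the range.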

Compound 4, half-maximal effective concentration: > 10000 nM
Compound 4 was reported as a limit (the forecaster's own chance of this, stated with the estimate: 10%); at least 200-fold (2.30 log units) between middle value and limit.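

In this assay, placing (4-isopropylpiperazin-1-yl)methyl on an aromatic carbon of the five-membered aromatic ring with 3 nitrogen gave an at least 280-fold higher number from compound 3 to compound 4 (2.45 log units; beyond the scatter), which means the effect on these cells now needs far larger amounts of compound. The reading for compound 4 is a limit of the assay, not an exact number: the limit of > 10000 nM in this assay, at which 1 of the 4 values shown sits. Among the compounds shown here, the earlier step that brought this ring in was a 1.0-fold lower number from compound 2 to compound 3 (0.01 log units; within the scatter), so the earlier compounds gave no sign that a single addition to the ring could shift the read-out so strongly, whereas compound 4 shows that this carbon, which carried only hydrogen in compound 3, is a highly sensitive place to change.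

The compounds shown leave open whether the step comes from the piperazine ring, its isopropyl group or simply the bulk of the addition, and a plain methyl or a morpholin-4-ylmethyl group on the same carbon would help separate these possibilities. They also leave open how large the step really is, since only its lower bound can be read.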